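Acylating the free hydroxy of compound 1

The source may hold more compounds than are shown below. What is called first, only, known or untested is meant among the compounds shown, and "the series" means these compounds.

Among the compounds with values here, in an ADME assay on HepG2 2.2.15 cells (Homo sapiens) for cytotoxicity, read by MTT assay (a higher number here means that more compound is tolerated, a lower number that less compound is tolerated), compound 1 (`C=C1CC[C@@H]2[C@](C)(COC(=O)c3cccs3)[C@H](O)CC[C@@]2(C)[C@@H]1C/C=C1\C=COC1=O`) gives 2470000 nM, the higher of the two numbers known so far, while compound 2 (`C=C1CC[C@@H]2[C@](C)(COC(=O)c3ccccc3)[C@H](O)CC[C@@]2(C)[C@@H]1C/C=C1\C=COC1=O`) gives 82000 nM. Within the data shown here, the one measured step, a 30-fold lower number from compound 1 to compound 2 (1.48 log units; beyond the scatter), is large and lies beyond the scatter, and it comes from phenyl in place of thiophen-2-yl on a carbonyl carbon. Compound 3 (`C=C1CC[C@@H]2[C@](C)(COC(=O)c3cccs3)[C@H](OC(=O)c3cccs3)CC[C@@]2(C)[C@@H]1C/C=C1\C=COC1=O`) differs from compound 1 elsewhere, with (thiophen-2-yl)carbonyl in place of hydrogen on an oxygen on a saturated carbon. Among the measured compounds shown here, no measured step covers this change, so the step to compound 2 offers only a rough guide to size. Since compound 1 stands at the top, a lower number is expected, in a step somewhat smaller than that one. The expected step is an 8.2-fold lower number from compound 1 to compound 3 (0.92 log units; beyond the scatter). For compound 3 the estimated value is 300000 nM, with an expected range of 60000 nM to 1500000 nM.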

Compound 3, half-maximal cytotoxic concentration: 1370000 nM
Compound 3: the middle estimate sits 4.6-fold (0.66 log units) below what was measured; the measured number falls inside the stated range.
By their numbers in this assay, from the lowest: compound 2; then compounds 3 and 1 (each within the scatter of the next).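

Replacing hydrogen with (thiophen-2-yl)carbonyl on the oxygen on a saturated carbon gives a 1.8-fold lower number from compound 1 to compound 3 (0.26 log units; within the scatter) in this assay, so at this position the change from hydroxy to ((thiophen-2-yl)carbonyl)oxy leaves the number within the scatter. The change at the other ester, by contrast, gives a 30-fold lower number from compound 1 to compound 2 (1.48 log units; beyond the scatter), so the number shifts beyond the scatter with a change at that place but not with this one. Nothing measured here explains this difference between the two places.

The compounds shown leave open whether this tolerance is particular to (thiophen-2-yl)carbonyl or extends to other groups on the same oxygen, such as an acetyl or a benzoyl group. They also leave open what an amine in place of the hydroxy would do to the number.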